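The source may report more compounds than this note shows. Statements on the series, on what has been measured and on what is new or still open speak of the compounds shown alone.

Measured so far:
- compound 1 `Cc1cc(O)c(C(=O)/C=C/c2cccc3ccccc23)c(-c2ccc(Cl)cc2)c1C(=O)/C=C/c1cccc2ccccc12`: in a functional assay on MCF7 cells (Homo sapiens) for cytotoxicity, read by MTT assay, with a stated time of 24 h (on this read-out lower numbers stand for stronger inhibition and higher numbers for weaker inhibition), compound 1 gives 30000 nM
- compound 2 `Cc1cc(O)c(C(=O)/C=C/c2ccc(OCc3ccccc3)cc2)c(-c2ccc(Br)cc2)c1C(=O)/C=C/c1ccc(OCc2ccccc2)cc1`: in this assay compound 2 gives 20000 nM

Compound 2 holds the lower of the two numbers in this assay, and compound 1 sits within the scatter of it, so the two cannot be ordered. Compound 3 `Cc1cc(O)c(C(=O)/C=C/c2ccc(OCc3ccccc3)cc2)c(-c2ccc(OCc3ccccc3)cc2)c1C(=O)/C=C/c1ccc(OCc2ccccc2)cc1` is not yet measured. Compared with compound 2 it carries benzyloxy in place of bromo on an aromatic carbon. Going by the values given here, no measured pair isolates this change, so nothing in the data shows which way it moves the number; the expectation is no step beyond the scatter, or at most a small one. For compound 3 the estimated value in this assay is 20000 nM (range 8000 nM to 50000 nM), the step from compound 2 being expected as no change at the digits printed from compound 2 to compound 3 (within the scatter).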

Compound 3, half-maximal inhibitory concentration: 26000 nM
Compound 3: middle estimate off by 1.3-fold (0.11 log units), on the low side, within the range that was stated.
By their numbers in this assay, from the lowest: compounds 2, 3 and 1 (each within the scatter of the next).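

In this assay, going by these compounds alone, the only pair isolating this position shows a 1.3-fold higher number from compound 2 to compound 3 (0.11 log units; within the scatter) on exchanging bromo for benzyloxy on an aromatic carbon para to a large group. Although benzyloxy brings a six-membered aromatic ring of carbon only and a hydrogen-bond acceptor, the two groups cannot be told apart at this position in this read-out. No separate measurement bears on the reason for this result.

From the compounds shown here alone, whether an amine or a carboxylic acid at this position would give a step beyond the scatter remains open. Also open, going by these compounds, is whether the same exchange gives a similar result with naphthyl arms in place of the benzyloxy-bearing arms on the core.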